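Moving a Fluorine Around the Sulfonyl Ring

This account rests on a few compounds, and the source may have more. Where it says the series, first, only, none or still open, it means among the compounds named here.

Of the compounds shown here, two have been measured in an in vitro assay on HEK ts201 cells for negative allosteric modulation of Neuronal acetylcholine receptor; alpha4/beta2 (Homo sapiens), read by fluorescence and calcium flux, with a stated time of 1.5 s; a higher number here means a weaker inhibitor, a lower number a stronger inhibitor. Compound 1, with the structure `COC(=O)c1ccc(NC(=O)CN2CCN(S(=O)(=O)c3ccccc3F)CC2)cc1`, gives 12400 nM in this assay. Compound 2, with the structure `O=C(CN1CCN(S(=O)(=O)c2ccc(F)cc2)CC1)Oc1ccccc1-c1ccccc1`, gives 12200 nM in this assay. Compound 2 has the lowest of the two numbers, but compound 1 sits so close to it that the gap lies within the usual scatter of repeated measurements, so neither can be called the stronger of the pair. Both numbers are high, meaning weak inhibition.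

Compound 3, with the structure `O=C(CN1CCN(S(=O)(=O)c2ccccc2F)CC1)Oc1ccccc1-c1ccccc1`, has not yet been measured. It differs from compound 2 in one place only: 2-fluorophenyl in place of 4-fluorophenyl on a sulfonyl sulfur. The rest of the molecule is unchanged, and the two compounds hold the same atoms joined differently.

For the measured compounds named here, no step between measured compounds shows what this change does here. Compound 1, which already carries the 2-fluorophenyl on its sulfonyl sulfur with a different other half, gives 12400 nM, a weak number like that of compound 2. The step of a 1.0-fold higher number from compound 2 to compound 3 (0.01 log units; within the scatter) is therefore expected to be none beyond the scatter. Compound 3 is estimated to give 12500 nM in this assay, with a range from 5000 nM to 32000 nM.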

Compound 3, half-maximal inhibitory concentration: 20900 nM
Compound 3: the middle estimate sits 1.7-fold (0.22 log units) below what was measured; measured number inside the range.
By their numbers in this assay, from the lowest: compounds 2, 1 and 3 (each within the scatter of the next).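

In this assay, for the compounds shown here, the change to 2-fluorophenyl in place of 4-fluorophenyl on a sulfonyl sulfur gives a 1.7-fold higher number from compound 2 to compound 3 (0.23 log units; within the scatter) and is the first reading of this change with the rest of the molecule held the same. Compound 1 and compound 2 differ in more than one place, so they could not show this, whereas compound 2 and compound 3 hold the same atoms and differ only in where the fluorine sits on the sulfonyl ring, and that shift does not separate them beyond the usual scatter of repeated measurements. Nothing measured here bears on why the two numbers fall where they do.

The compounds shown leave open whether the same change would read alike with the rest of compound 1, as the pair needed for that comparison does not stand among them. They also leave open whether an amine, a carboxylic acid or a methoxy group in place of the fluorine on the sulfonyl ring would move the number beyond the scatter, since every sulfonyl ring shown here carries fluorine and nothing else.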